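Working notes: from compound 3 to compound 4

This account rests on a few compounds, and the source may have more. Where it says the series, first, only, none or still open, it means among the compounds named here.

Values in a functional assay on HCT-116 cells (Homo sapiens) for cytotoxicity, read by MTT assay, with a stated time of 72 h (a higher number here means a weaker inhibitor, a lower number a stronger inhibitor), so far:
- compound 1 `O=C1c2c[n+]([O-])c3ccccc3c2C(=O)c2c1c1ccccc1n2Cc1cn([C@H]2O[C@H](CO)[C@@H](O)[C@H]2O)nn1` gives 710 nM
- compound 2 `CC1(C)OCC(Cn2cc(Cn3c4c(c5ccccc53)C(=O)c3c[n+]([O-])c5ccccc5c3C4=O)nn2)O1` gives 70 nM
- compound 3 `CN1CCN(CCCCCCn2c3c(c4ccccc42)C(=O)c2c[n+]([O-])c4ccccc4c2C3=O)CC1` gives 2900 nM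

Compound 3 has the highest number of the three, with compound 1 nearest to it and compound 2 furthest away. Not yet measured is compound 4 `O=C1c2c[n+]([O-])c3ccccc3c2C(=O)c2c1c1ccccc1n2Cc1cn(C[C@@H](O)CO)nn1` and the change is 1-(2,3-dihydroxypropyl)-1H-1,2,3-triazol-4-yl in place of 5-(4-methylpiperazin-1-yl)pentyl on a saturated chain carbon bound to an aromatic nitrogen in words 1-(2,3-dihydroxypropyl)-1H-1,2,3-triazol-4-yl in place of 5-(4-methylpiperazin-1-yl)pentyl on a saturated chain carbon bound to an aromatic nitrogen.

Among the compounds with values here, no measured step covers this exchange directly. Within the data shown here, the one step available is a 10-fold lower number from compound 1 to compound 2 (1.01 log units; beyond the scatter) and it is large, so the group on the triazole can matter a great deal. Both of its compounds carry the triazole and both lie below compound 3 on the numbers. Compound 4 keeps free hydroxyl groups, as does compound 1 at 710 nM so it is expected closer to that compound than to compound 2. Three compounds make a thin basis for this.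

A lower number is therefore expected, beyond the scatter, and the estimated change is a 5.8-fold lower number from compound 3 to compound 4 (0.76 log units; beyond the scatter) in this assay on this reasoning. For compound 4 the estimated value is 500 nM with an expected range of 150 nM to 1800 nM for now.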

Compound 4, half-maximal inhibitory concentration: 190 nM
Estimate against measurement, compound 4: 2.6-fold (0.42 log units) above, within the range that was stated.
By their numbers in this assay, from the lowest: compound 2; then compound 4; then compound 1; then compound 3.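

In this assay, within the data shown here, the exchange of 5-(4-methylpiperazin-1-yl)pentyl for 1-(2,3-dihydroxypropyl)-1H-1,2,3-triazol-4-yl on a saturated chain carbon bound to an aromatic nitrogen gives a 15-fold lower number from compound 3 to compound 4 (1.18 log units; beyond the scatter) and so shows, for the first time, that a large step is possible between a triazole compound and the piperazine compound differing in this one place. Free hydroxyl groups do not tie a compound to the higher numbers, since 2,3-dihydroxypropyl in place of 3,4-dihydroxy-5-(hydroxymethyl)oxolan-2-yl gives a 3.7-fold lower number from compound 1 to compound 4 (0.57 log units; beyond the scatter) even though both groups carry them, while 1,2-dihydroxyethyl in place of 2,2-dimethyl-1,3-dioxolan-4-yl gives a 2.7-fold higher number from compound 2 to compound 4 (0.43 log units; beyond the scatter) and leaves compound 2 with the lowest number of the four. Nothing available explains any of these steps, so they stand as observed differences only.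

As far as these compounds go, the step from compound 3 to compound 4 changes the chain, the triazole and the terminal group at once, so the share of each remains open. A triazole carrying 4-methylpiperazine, or a pentyl chain ending in a hydroxyl group, would separate these contributions in this assay and show which part of the step belongs to the amine.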